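The compounds below may be only part of what the source reports. "The series", "measured", "known", "first", "only" and "open" are said of these compounds alone.

Measured compounds:
compound 1 `Cc1cc(=O)n(-c2cccc(F)c2)nc1C(=O)Nc1ccc(Oc2ncnc3ccsc23)c(F)c1`, which gives 5220 nM in a functional assay on A549 cells (Homo sapiens) for cytotoxicity, read by MTT assay, with a stated time of 72 h; on this read-out higher numbers stand for weaker inhibition and lower numbers for stronger inhibition;
compound 2 `Cc1ccc(-n2nc(C(=O)Nc3ccc(Oc4ncnc5ccsc45)c(F)c3)c(C)cc2=O)cc1`, which gives 5890 nM in this assay;
compound 3 `Cc1cc(=O)n(-c2cccc(F)c2)nc1C(=O)Nc1ccc(Oc2ncnc3sccc23)cc1`, which gives 16400 nM in this assay.

Compound 4 `Cc1ccc(-n2nc(C(=O)Nc3ccc(Oc4ncnc5sccc45)cc3)c(C)cc2=O)cc1` has not yet been measured in this assay. Compound 2 carries 4-methylphenyl in place of 3-fluorophenyl on an aromatic nitrogen relative to compound 1, and this change gave a 1.1-fold higher number from compound 1 to compound 2 (0.05 log units; within the scatter). Compound 4 carries 4-methylphenyl in place of 3-fluorophenyl on an aromatic nitrogen relative to compound 3, the same change at the same place; the difference between the core of compound 1 and the core of compound 3 is not broken down here. Because a 1.1-fold higher number from compound 1 to compound 2 (0.05 log units; within the scatter) lay within the scatter, compound 4 is expected to sit close to compound 3, with a step of about a 1.1-fold higher number from compound 3 to compound 4 (0.03 log units; within the scatter). The estimate for compound 4 is therefore 17500 nM, between 9000 nM and 35000 nM, resting on one earlier step only.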

Compound 4, half-maximal inhibitory concentration: > 40000 nM
Compound 4: a limit, no number; the forecaster's own chance of this, stated with the estimate: 10%; middle value at least 2.2-fold (0.35 log units) away from the limit.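

Compound 4 gives > 40000 nM in this assay, which is a limit of the assay and not a number. Putting 4-methylphenyl in place of 3-fluorophenyl on the aromatic nitrogen gave an at least 2.4-fold higher number from compound 3 to compound 4 (0.38 log units; beyond the scatter). So a step within the scatter on one core did not foretell a step within the scatter on the other, yet how far the two steps differ stays open: the same change on two cores in this assay, a 1.1-fold higher number (0.05 log units; within the scatter) from compound 1 to compound 2 and an at least 2.4-fold higher number (0.38 log units; beyond the scatter) from compound 3 to compound 4; the limit leaves it open whether they differ

The compounds shown leave open how the two cores would respond to a phenyl ring bearing an amine or a carboxylic acid on that nitrogen. They also do not separate which part of the difference between the two cores goes with the second step.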